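The source may hold more compounds than are shown below. What is called first, only, known or untested is meant among the compounds shown, and "the series" means these compounds.

Measured compounds:
compound 1 `CCCCNc1nc(N)nc(C)c1CCCN1CCCCC1` with 133 nM
compound 2 `CCCCNc1nc(N)nc(C)c1CC` with 1660 nM

In an assay on HEK293 cells for agonist activity at Toll-like receptor 8 (Homo sapiens), read by spectrophotometry (on this read-out higher numbers stand for an effect only at larger amounts of compound and lower numbers for an effect already at smaller amounts), compound 2 holds the highest of the two numbers; compound 1 lies at 133 nM, and the two are separated by the step of a 12-fold higher number from compound 1 to compound 2 (1.10 log units; beyond the scatter). That step removed the (piperidin-1-yl)methyl from the saturated chain carbon two bonds along the chain from an aromatic carbon.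

Compound 3 `CCCCNc1nc(N)nc(C)c1CCCN(C)C` differs from compound 2 by (dimethylamino)methyl in place of hydrogen on a saturated chain carbon, two bonds along the chain from an aromatic carbon. It thus puts an amine-bearing group back onto the same chain carbon that was bared in the step from compound 1 to compound 2. Within the data shown here, only that measured step bears on the change, and it was large, so the step from compound 2 to compound 3 is expected to run the other way, towards a markedly lower number, by roughly a 7.5-fold lower number from compound 2 to compound 3 (0.88 log units; beyond the scatter), perhaps not fully matching the size seen between compound 1 and compound 2. For compound 3 the estimated value in this assay is 220 nM, with a likely range of 80 nM to 600 nM.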

Compound 3, half-maximal effective concentration: 126 nM
Compound 3: the middle estimate sits 1.7-fold (0.24 log units) above what was measured; the range from low to high includes it.
By their numbers in this assay, from the lowest: compounds 3 and 1 (each within the scatter of the next); then compound 2.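

In this assay, the gain at this chain carbon is not tied to piperidin-1-yl: (dimethylamino)methyl in place of hydrogen gives a 13-fold lower number from compound 2 to compound 3 (1.12 log units; beyond the scatter) and is printed as a large step, as is the one involving (piperidin-1-yl)methyl. Exchanging the two amines gives a 1.1-fold lower number from compound 1 to compound 3 (0.02 log units; within the scatter) and so leaves dimethylamino and piperidin-1-yl, three bonds along the chain from an aromatic carbon, without any order on this read-out. Nothing at hand explains why either amine-bearing chain gives this result.

Going by these compounds, whether the step depends on the amine nitrogen or only on the added chain stays open: a hydroxyl or a plain propyl group at the same carbon would separate the two. On these data alone, how a primary amine, morpholin-4-yl or a longer chain ending in dimethylamino would read also remains open.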